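The compounds below may be only part of what the source reports. "The series", "measured", "known", "first", "only" and "open" are said of these compounds alone.

Measured compounds:
Compound 1 `O=S(=O)(NCC1CCN(CCCc2c[nH]c3ccc(-n4cnnc4)cc23)CC1)c1ccccc1` gives 6.2 nM
Compound 2 `O[C@@H]1Cc2ccccc2[C@H]1NC1CCN(CCCc2c[nH]c3ccc(-n4cnnc4)cc23)CC1` gives 6.6 nM

Both numbers come from an assay on CHO cells for displacement of a labelled ligand from 5-hydroxytryptamine receptor 1D (Homo sapiens); a lower number here means a stronger inhibitor, a higher number a weaker inhibitor. Going by the values given here, compound 2 has the higher of the two, yet its only neighbour, compound 1, sits within the scatter: a 1.1-fold higher number from compound 1 to compound 2 (0.03 log units; within the scatter). Compound 3 `C[C@H](NCC1CCN(CCCc2c[nH]c3ccc(-n4cnnc4)cc23)CC1)c1ccccc1` differs from compound 2 by ((1-phenylethyl)amino)methyl in place of (2-hydroxy-2,3-dihydro-1H-inden-1-yl)amino on a saturated ring carbon. Among the compounds with values here, the single measured step, a swap of the group on the same saturated ring carbon, did not move the number beyond the scatter, so this further swap is expected to change it little: a 1.1-fold higher number from compound 2 to compound 3 (0.03 log units; within the scatter). Compound 3 is therefore estimated at 7 nM, with a range from 2.5 nM to 20 nM.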

Compound 3, half-maximal inhibitory concentration: 4.4 nM
Estimate against measurement, compound 3: 1.6-fold (0.20 log units) above; low and high end bracket the measured number.
By their numbers in this assay, from the lowest: compounds 3, 1 and 2 (each within the scatter of the next).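

In this assay, a third group on the saturated ring carbon leaves the number within the scatter (a 1.5-fold lower number from compound 2 to compound 3 (0.18 log units; within the scatter)). Exchanging phenylsulfonyl for 1-phenylethyl on the amine nitrogen likewise stays within the scatter (a 1.4-fold lower number from compound 1 to compound 3 (0.15 log units; within the scatter)), so these three quite different groups cannot be told apart here. Nothing available accounts for this tolerance.

Going by these compounds, whether a plain amine or a carboxylic acid on this ring carbon would keep the number in this range stays open. So does the effect of the opposite configuration at the 1-phenylethyl stereocentre.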